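Shortening the fatty acyl chain on a cytosine nucleoside ester

The source may hold more compounds than are shown below. What is called first, only, known or untested is meant among the compounds shown, and "the series" means these compounds.

Three esters of the same nucleoside core have been tested. Compound 1 `CCCCCCCCCCCCCCCCCCCCCC(=O)O[C@H]1[C@H](O)[C@H](n2ccc(N)nc2=O)O[C@@H]1CO` carries the longest saturated chain; compound 2 `CCCCCCCCCCCCCCCC(=O)O[C@H]1[C@H](O)[C@H](n2ccc(N)nc2=O)O[C@@H]1CO` a shorter one; compound 3 `CCCCCCCC/C=C\CCCCCCCCCCCC(=O)O[C@H]1[C@H](O)[C@H](n2ccc(N)nc2=O)O[C@@H]1CO` a long chain with one double bond. In a functional assay on HeLa cells (Homo sapiens) for cytotoxicity, read by cell counting, with a stated time of 48 h (a lower number here means that less compound is needed, a higher number that more compound is needed for the effect), compound 1 gives 1.1 ug/mL, compound 2 gives 0.24 ug/mL, and compound 3 gives 0.16 ug/mL. Compound 2 therefore stands second highest of the three, close to compound 3 and well apart from compound 1.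

Compound 4 `CCCCCCCCC(=O)O[C@H]1[C@H](O)[C@H](n2ccc(N)nc2=O)O[C@@H]1CO` is compound 2 with a much shorter chain: hydrogen in place of heptyl on a saturated chain carbon, eight bonds along the chain from a carbonyl carbon. For the measured compounds named here, only one measured step cuts a saturated chain in the same way, and it points downward: a 4.6-fold lower number from compound 1 to compound 2 (0.66 log units; beyond the scatter). The other steps, a 6.9-fold lower number from compound 1 to compound 3 (0.84 log units; beyond the scatter) and a 1.5-fold lower number from compound 2 to compound 3 (0.18 log units; within the scatter), introduce a double bond and say less about plain shortening. Whether the trend from compound 1 to compound 2 continues when a further seven chain carbons are removed cannot be read from these three compounds, so the expectation is a modest further drop at most, with a wide range.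

Compound 4 is expected to give about 0.15 ug/mL in this assay, between 0.05 ug/mL and 0.5 ug/mL, which means an estimated step of a 1.6-fold lower number from compound 2 to compound 4 (0.20 log units; within the scatter).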

Compound 4, concentration for half-maximal effect: 0.05 ug/mL
Beside the measured number, compound 4's estimate is 3.0-fold (0.48 log units) above it, within the range that was stated.
By their numbers in this assay, from the lowest: compound 4; then compounds 3 and 2 (each within the scatter of the next); then compound 1.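

Removing heptyl, on a saturated chain carbon eight bonds along the chain from a carbonyl carbon, gives a 4.8-fold lower number from compound 2 to compound 4 (0.68 log units; beyond the scatter) in this assay and shows that the earlier drop was not confined to the longest chain. Together with a 4.6-fold lower number from compound 1 to compound 2 (0.66 log units; beyond the scatter) there are now two cuts of a saturated chain, each beyond the scatter and each lowering the number, so for these saturated esters a long chain is not needed for the effect on HeLa cells, and neither cut goes against the other. No measurement at hand explains why the shorter chain needs less compound.

The compounds shown stop at compound 4, so it stays open whether the number keeps falling with a still shorter chain, such as an acetyl ester, or turns upward again on the way to the shared core with hydrogen in place of the whole acyl group. Also open, from the compounds shown here alone, is what an amine or a carboxylic acid at the far end of the chain would do, and whether the same trend holds in cells other than HeLa.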